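The compounds below may be only part of what the source reports. "The series", "measured", "known", "first", "only" and "open" are said of these compounds alone.

Three compounds have been measured in a functional assay on Shh Light II cells (Mus musculus) for inhibition, read by a luciferase reporter; a lower number here means a stronger inhibitor, a higher number a weaker inhibitor:
Compound 1 `COc1ccccc1N(C)C(=O)N1CCC(c2nc(-c3ccc4ccccc4n3)no2)CC1` gives 3100 nM.
Compound 2 `Cn1c(-c2noc(C3CCN(C(=O)NC4CCS(=O)(=O)CC4)CC3)n2)nc2ccccc21` gives 350 nM.
Compound 3 `Cn1c(-c2noc(N3CCN(C(=O)NC4CCCCC4)CC3)n2)nc2ccccc21` gives 5 nM.

Among these, compound 1 gives the highest number and is thus the weakest inhibitor of the three; its gaps to compound 2 and to compound 3 both lie beyond the usual scatter of repeated measurements. Compound 4 `O=C(OCc1ccccc1)N1CCC(c2nc(-c3ccc4ccccc4n3)no2)CC1` differs from compound 1 in one place: benzyloxy in place of (2-methoxyphenyl)(methyl)amino on a carbonyl carbon. For the measured compounds named here, no measured pair shows this same change, so there is no direct guide to its size. The shared core of compound 1 stays untouched, and the step of a 1.6-fold lower number from compound 1 to compound 4 (0.19 log units; within the scatter) is expected to be small, close to the scatter, if anything slightly downward. Compound 4 is therefore estimated at 2000 nM, within a range from 500 nM to 8000 nM.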

Compound 4, half-maximal inhibitory concentration: > 2500 nM
Compound 4 was reported as a limit; the forecaster's own chance of this, stated with the estimate: 10%; middle value at least 1.2-fold (0.09 log units) from the limit.
By their numbers in this assay, from the lowest: compound 3; then compound 2; then compound 1.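

In this assay compound 4 gives > 2500 nM, which is a limit and not a number, and the step from compound 1 to compound 4 cannot be read. The compounds shown leave open whether benzyloxy in place of (2-methoxyphenyl)(methyl)amino changes the number at all.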